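The source may hold more compounds than are shown below. What is called first, only, known or untested is meant among the compounds shown, and "the series" means these compounds.

Of the compounds shown here, three sharing one core have been measured in a functional assay on MDA-MB-231 cells (Homo sapiens) for cytotoxicity; a higher number here means a weaker inhibitor, a lower number a stronger inhibitor. Compound 1 `COc1ccc(Cn2cc(/C=N\NC(=O)c3c[nH]c4ccccc34)c3ccccc32)cc1` gives 15100 nM in this assay. Compound 2 `COc1ccc(Cn2cc(/C=N\NC(=O)c3c[nH]c4ccc(Br)cc34)c3cc(OC)ccc32)cc1` gives 61200 nM. Compound 3 `COc1ccc2c(c1)c(/C=N\NC(=O)c1c[nH]c3ccc(Br)cc13)cn2Cc1ccc(Cl)cc1` gives 5000 nM, the lowest of the three numbers; compound 1 stands nearest to it and compound 2 furthest. Compound 1 and compound 2 differ in more than one place, so their values can only be set side by side. Among the compounds with values here, the single one-place change among the measured compounds is a 12-fold lower number from compound 2 to compound 3 (1.09 log units; beyond the scatter).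

Compound 4 `COc1ccc2c(c1)c(/C=N\NC(=O)c1cn(C)c3ccccc13)cn2Cc1ccc(Cl)cc1` has not yet been measured. It differs from compound 3 by 1-methyl-1H-indol-3-yl in place of 5-bromo-1H-indol-3-yl on a carbonyl carbon. Within the data shown here, none of the measured steps touches this part of the molecule: the only measured step concerns a change elsewhere in the structure, and its size says nothing about an exchange at the carbonyl carbon. The values of compound 1 and compound 2 show that a set of changes including a bromine went with a higher number, but those two compounds differ in two places. Among the measured compounds shown here, with no step bearing on the change, the step of a 1.4-fold higher number from compound 3 to compound 4 (0.15 log units; within the scatter) is expected to stay within the scatter. Compound 4 is therefore expected to give about 7000 nM, between 2500 nM and 25000 nM.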

Compound 4, half-maximal inhibitory concentration: > 100000 nM
Compound 4: a limit, no number (the forecaster's own chance of this, stated with the estimate: 5%); at least 14-fold (1.15 log units) between middle value and limit.
By their numbers in this assay, from the lowest: compound 3; then compound 1; then compound 2. At a limit, above all of these: compound 4.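

Compound 4 gives only a limit in this assay, > 100000 nM, and not a number. Within the data shown here, the exchange on the carbonyl carbon, whose other neighbour is an amide-type nitrogen, produces an at least 20-fold higher number from compound 3 to compound 4 (1.30 log units; beyond the scatter), so this position, which no earlier one-place step had touched, is far from indifferent: with the rest of compound 3 held fixed, replacing 5-bromo-1H-indol-3-yl with 1-methyl-1H-indol-3-yl is enough for a large loss. The full size of this loss cannot be read from the result, as the step rests on a limit and not on a number: the limit of > 100000 nM in this assay, at which 1 of the 4 values shown sits.

The exchange removes the bromine and adds the methyl at once, taking the count from 1 hydrogen-bond donor to 0 hydrogen-bond donors, so the compounds shown cannot say which of these differences carries the step, or whether both do. Also open, on these data alone, is how an indole with both the bromine and the methyl would behave on this core, and how an ethyl or longer chain in place of the methyl, or an amine or a carboxylic acid in place of the bromine, would read in this assay.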